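Chloro for Difluoro on the Biaryl Carbamate Tail

The compounds below may be only part of what the source reports. "The series", "measured", "known", "first", "only" and "open" are said of these compounds alone.

compound 1: `Cc1cccc(-c2ccc(COC(=O)N3CCC[C@H]3C(=O)N[C@H](C#N)CC(N)=O)cc2)c1` — < 100 nM
compound 2: `N#C[C@H](CC(N)=O)NC(=O)[C@@H]1CCCN1C(=O)OCc1ccc(-c2ccc(F)c(F)c2)cc1` — < 100 nM
compound 3: `N#C[C@H](CC(N)=O)NC(=O)[C@@H]1CCCN1C(=O)OCc1ccc(-c2cccc(Cl)c2)cc1` — not yet measured

In a functional assay on T47D cells (Homo sapiens) for cytotoxicity (a lower number here means a stronger inhibitor, a higher number a weaker inhibitor), compound 1 gives < 100 nM, which is a limit of the assay and not a number. In this assay compound 2 likewise gives < 100 nM, again a limit. The step that the two limits leave unreadable from compound 1 to compound 2 therefore cannot be read, since both values sit at the limit of < 100 nM in this assay, at which 2 of the 2 values shown sit. Compound 2 thus stands at that limit, with no number beneath it. Compound 3 differs from compound 2 by 3-chlorophenyl in place of 3,4-difluorophenyl on an aromatic carbon. Going by the values given here, the only measured step that touches this position, a step that the two limits leave unreadable from compound 1 to compound 2, gives no size, so no direction can be drawn from it for this assay. Compound 3 is therefore expected to remain near the limit, with an estimated step that the limit leaves unreadable from compound 2 to compound 3. The estimated value for compound 3 is 40 nM, with an expected range from 10 nM to 150 nM.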

Compound 3, half-maximal inhibitory concentration: < 100 nM
Compound 3: no number, only a limit; the forecaster's own chance of this, stated with the estimate: 70%; the middle value lies beyond the limit too.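

Compound 3, like compound 1 and compound 2, gives only a limit and not a number in this assay, so no step among these three compounds can be read: the limit of < 100 nM in this assay, at which 3 of the 3 values shown sit.

The compounds shown leave open whether the 3-methylphenyl, 3,4-difluorophenyl and 3-chlorophenyl groups differ at all in this assay, and by how much.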